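The source may report more compounds than this note shows. Statements on the series, on what has been measured and on what is new or still open speak of the compounds shown alone.

Measured so far:
compound 1 `Cc1ccc(S(=O)(=O)Nc2ccc(S(N)(=O)=O)cc2)cc1` — 14500 nM
compound 2 `NS(=O)(=O)c1ccc(NS(=O)(=O)c2ccc(F)cc2)cc1` — 1130 nM

In an assay on isolated protein for inhibition of Intestinal-type alkaline phosphatase (Bos taurus), read by chemiluminescence and spectrophotometry (on this read-out higher numbers stand for weaker inhibition and lower numbers for stronger inhibition), compound 2 gives 1130 nM, the lowest of the two numbers; the nearest is compound 1 with 14500 nM. Among the compounds with values here, the one measured step, a 13-fold lower number from compound 1 to compound 2 (1.11 log units; beyond the scatter), concerns the fluoro for methyl exchange on the other ring and says nothing about the group discussed here.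

Compound 3 `CCOc1ccc(NS(=O)(=O)c2ccc(F)cc2)cc1` is not yet measured. Its difference from compound 2 is ethoxy in place of sulfamoyl on an aromatic carbon, the place being an aromatic carbon of a six-membered aromatic ring of carbon only, para to a large group. No measured step bears on this exchange, so there is no shown precedent for its size or direction; the sulfamoyl is carried by both measured compounds and its removal is untested in this series.

For compound 3 a weaker result than compound 2 is expected, an estimated step of a 3.5-fold higher number from compound 2 to compound 3 (0.55 log units; beyond the scatter), with a wide range. The estimate for compound 3 in this assay is 4000 nM, between 700 nM and 25000 nM.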

Compound 3, half-maximal inhibitory concentration: 720 nM
For compound 3 the middle estimate is 5.6-fold (0.74 log units) above the measured one; measured number inside the range.
By their numbers in this assay, from the lowest: compounds 3 and 2 (each within the scatter of the next); then compound 1.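

In this assay, ethoxy in place of sulfamoyl on an aromatic carbon, para to a large group, gives a 1.6-fold lower number from compound 2 to compound 3 (0.20 log units; within the scatter), so compound 2 and compound 3 cannot be told apart on this read-out. Within the data shown here, this is the first sign that, with the fluoro group held constant, the sulfamoyl carried by compound 1 and compound 2 is not needed to keep the number at this level: it can leave, with its hydrogen-bond donor, and ethoxy can enter without a change beyond the scatter. No measurement at hand accounts for the two groups reading alike.

Still open, from the compounds shown here alone, is whether this tolerance extends beyond ethoxy at this carbon, for example to an amine, a carboxylic acid or a longer chain such as butoxy. Also open, going by these compounds, is whether the step seen with sulfamoyl in place, a 13-fold lower number from compound 1 to compound 2 (1.11 log units; beyond the scatter), carries over when ethoxy occupies this position, which would take the methyl counterpart of compound 3.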